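The source may report more compounds than this note shows. Statements on the series, on what has been measured and on what is new or still open speak of the compounds shown alone.

Measured so far:
compound 1, `CCOP(=O)(O)OC[C@H]1O[C@@H](n2ccc(N)nc2=O)[C@@H](O)[C@@H]1O` — in a functional assay on B16 cells (Mus musculus) for inhibition (on this read-out lower numbers stand for stronger inhibition and higher numbers for weaker inhibition), compound 1 gives 70 uM
compound 2, `CCCCOP(=O)(O)OC[C@H]1O[C@@H](n2ccc(N)nc2=O)[C@@H](O)[C@@H]1O` — in this assay compound 2 gives 130 uM

Compound 2 holds the highest of the two numbers, its nearest neighbour being compound 1, and a 1.9-fold higher number from compound 1 to compound 2 (0.27 log units; within the scatter). Compound 3, `CCCCCCCCOP(=O)(O)OC[C@H]1O[C@@H](n2ccc(N)nc2=O)[C@@H](O)[C@@H]1O`, carries the change (butyl in place of hydrogen on a saturated chain carbon, four bonds along the chain from an oxygen on an unsaturated carbon). Within the data shown here, the only measured step that bears on it is the chain growth from compound 1 to compound 2, which stayed within the scatter. Lengthening the chain once more is therefore expected to move this assay little, if at all, and if anything upward, as a 1.2-fold higher number from compound 2 to compound 3 (0.09 log units; within the scatter). Compound 3 is estimated at 160 uM, within 50 uM to 500 uM.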

Compound 3, concentration for 50% inhibition: 360 uM
Compound 3: the middle estimate sits 2.3-fold (0.35 log units) below what was measured, and the stated range covers the measured number.
By their numbers in this assay, from the lowest: compounds 1 and 2 (each within the scatter of the next); then compound 3.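

In this assay lengthening the chain now has a readable effect: a 2.8-fold higher number from compound 2 to compound 3 (0.44 log units; beyond the scatter) lies beyond the scatter, unlike the earlier growth from compound 1 to compound 2. Over the whole change, a 5.1-fold higher number from compound 1 to compound 3 (0.71 log units; beyond the scatter) is also beyond the scatter, so clearly weaker inhibition appears here only with the longest chain. Nothing available explains this rise.
As far as these compounds go, whether a still longer chain would weaken inhibition further stays open. So does how an amine or a carboxylic acid would behave at this place on the chain.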